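The compounds below may be only part of what the source reports. "The series", "measured", "known", "first", "only" and "open" are said of these compounds alone.

Measured compounds in this set:
- compound 1, `CCCn1cnc2c(N)nc(NCCCc3ccccc3)nc21`. In a functional assay on CHO cells for antagonist activity at adenosine receptor A2b (Homo sapiens) (on this read-out lower numbers stand for stronger inhibition and higher numbers for weaker inhibition), compound 1 reports only a limit of the assay, > 30000 nM.
- compound 2, `CCCn1cnc2c(NCCCc3ccccc3)ncnc21`. In this assay compound 2 likewise reports only a limit of the assay, > 30000 nM.

Compound 2 therefore stands at the edge of what this assay resolves, not at a number; the same holds for the other measured value, as noted in the limit of > 30000 nM in this assay, at which 2 of the 2 values shown sit. For the measured compounds named here, no pair of measured compounds differs in a single place, so no measured step is available to calibrate the next change.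

Compound 3, `CCCn1c(Br)nc2c(NCCCc3ccccc3)ncnc21`, departs from compound 2 by bromo in place of hydrogen on an aromatic carbon. Because the two measured compounds both sit at the limit noted in the limit of > 30000 nM in this assay, at which 2 of the 2 values shown sit, the series gives no direction for this kind of change. Going by the values given here, the expectation for the step from compound 2 to compound 3 in this assay is an at least 1.2-fold lower number from compound 2 to compound 3 (0.07 log units; that floor lies within the scatter), that is, no step that can be told apart from the scatter, with a fair chance the read-out again ends in a limit. Compound 3 is accordingly estimated at 25000 nM, within 4000 nM to 100000 nM.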

Compound 3, inhibition constant: 1760 nM
Estimate against measurement, compound 3: 14-fold (1.15 log units) above, outside the stated range (below it).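

Bromo in place of hydrogen on an aromatic carbon, between two ring nitrogen atoms and next to the ring atom that bears a propyl group, gives the first step in this set that can be read in this assay: an at least 17-fold lower number from compound 2 to compound 3 (1.23 log units; beyond the scatter). That step is a floor and not an exact size, as compound 2 reports only a limit of the assay. A single heavy atom at this place on the five-membered aromatic ring is thus enough to bring compound 3 to a number on this read-out, whereas the other two compounds shown stay at the shared limit: the limit of > 30000 nM in this assay, at which 2 of the 3 values shown sit.

The compounds shown do not tell whether this shift is particular to bromo or would also come with chloro, a methyl group or an amine at the same carbon. Also open, as far as these compounds go, are whether bromo at this place gives a similar step on the core of compound 1, which carries a further amine, and whether it holds with a longer chain in place of the propyl group.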